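A few compounds are considered here, and "the series" means these few. Any claim that something is new, unique, unknown or untested is made for them only; others in the source may bear on it.

Measured compounds:
- compound 1, `CC(C)=CCC/C(C)=C/COc1ccc(/C=C/C(=O)O)cc1O` — in an assay on isolated protein for inhibition of geranylgeranyl pyrophosphate synthase (Homo sapiens), tested at 100 uM (a higher number here means more inhibition at the concentration tested (going by the name of the read-out), a lower number less inhibition), compound 1 gives 12.7%
- compound 2, `COc1cc(/C=C/C(=O)O)ccc1OCC=C(C)C` — in this assay compound 2 gives 9.3%

Both values are small, and the value of compound 2 lies within the usual scatter of the value of compound 1, so the two compounds cannot be told apart on these numbers; compound 2 simply sits at the low end of a pair that is, in effect, one level.

Compound 3, `COc1cc(C(=O)O)ccc1OCC=C(C)C`, has not been measured. It differs from compound 2 in a single place: carboxy in place of 2-carboxyethenyl on an aromatic carbon. The methoxy group and the (3-methylbut-2-en-1-yl)oxy group on the shared core stay as they are.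

For the measured compounds named here, no measured pair shows what this change does here. With both measured compounds already near the bottom of the scale, there is little room for a fall, and nothing in the data argues for a rise. The step from compound 2 to compound 3 is therefore expected to be a number 1.3 percentage points lower from compound 2 to compound 3 (within the scatter), none beyond the scatter. Compound 3 is estimated to give 8% in this assay, with a range from 0% to 22%.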

Compound 3, a percentage reported as inhibition, at one concentration (the size of the read-out at that concentration, not a potency): 2.4%
For compound 3 the middle estimate is 5.6 percentage points above the measured one; the range from low to high includes it.
By their numbers in this assay, from the lowest: compounds 3, 2 and 1 (each within the scatter of the next, the first and the last beyond it).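

Putting carboxy in place of 2-carboxyethenyl on this aromatic carbon, which is para to the (3-methylbut-2-en-1-yl)oxy group and meta to the methoxy group, gives a number 6.9 percentage points lower from compound 2 to compound 3 (within the scatter) in this assay. For the compounds shown here, this is the first direct reading at this position, and it shows that removing two carbons and a double bond from the side group, while the acid end and the counts of hydrogen-bond donors and acceptors stay the same, produces no change that can be told from the scatter, so inhibition stays low with either group. The data offer no measurement that could explain this outcome.

The compounds shown leave open whether any other group on this carbon, such as an amine, an amide or a longer chain ending in a carboxylic acid, would lift inhibition clear of the scatter. As far as these compounds go, it also remains open whether carboxy at this position would give the same reading if a longer chain replaced the (3-methylbut-2-en-1-yl)oxy group.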